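The compounds below may be only part of what the source reports. "The series", "measured", "known", "first", "only" and "open" are said of these compounds alone.

Measured so far in a functional assay on MCF7 cells (Homo sapiens) for cytotoxicity, read by MTT assay, with a stated time of 24 h; a lower number here means a stronger inhibitor, a higher number a weaker inhibitor:
compound 1 `Cc1ncc([N+](=O)[O-])n1CCOc1ccccc1` gives 106 ug/mL
compound 2 `Cc1ncc([N+](=O)[O-])n1CCOc1ccccc1Cl` gives 378 ug/mL
compound 3 `Cc1ncc([N+](=O)[O-])n1CCOc1ccc([N+](=O)[O-])cc1` gives 127 ug/mL

Compound 1 holds the lowest of the three numbers in this assay; compound 3 sits within the scatter of it, and only compound 2 lies clearly higher. Compound 4 `Cc1ncc([N+](=O)[O-])n1CCOc1cccc([N+](=O)[O-])c1` differs from compound 1 in one place: nitro in place of hydrogen on an aromatic carbon. The most relevant measured step is a 1.2-fold higher number from compound 1 to compound 3 (0.08 log units; within the scatter), the same group entering the same ring at another position, which moved the number hardly at all. The step of a 3.6-fold higher number from compound 1 to compound 2 (0.55 log units; beyond the scatter) shows that a substituent on this ring can raise the number modestly. Compound 4 is therefore expected to stay close to compound 1, a step of a 1.2-fold higher number from compound 1 to compound 4 (0.07 log units; within the scatter). Compound 4 is estimated at 125 ug/mL, with a range from 70 ug/mL to 230 ug/mL.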

Compound 4, half-maximal inhibitory concentration: 71.7 ug/mL
Compound 4: middle estimate off by 1.7-fold (0.24 log units), on the high side, and the stated range covers the measured number.
By their numbers in this assay, from the lowest: compounds 4, 1 and 3 (each within the scatter of the next); then compound 2.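

Placed meta to a large group, nitro gives a 1.5-fold lower number from compound 1 to compound 4 (0.17 log units; within the scatter) in this assay and so causes no clear shift at this position. Compound 3 and compound 4 both lie within the scatter of compound 1, whereas the chloro group of compound 2 gives the only clear rise. Nothing measured here explains why the number stays so close.

On these data alone, whether an amine or a carboxylic acid at this position would also leave the number unchanged remains open. So does whether chloro here would raise it.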